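Methyl addition on the aminopyrimidine series

The compounds below may be only part of what the source reports. "The series", "measured", "known", "first", "only" and "open" are said of these compounds alone.

Three compounds in the series have a number in a functional assay for inhibition, with Homo sapiens as the target; on this read-out lower numbers stand for stronger inhibition and higher numbers for weaker inhibition. Compound 3 `Cc1cc(-c2ccnc(Nc3ccccc3)n2)c(C)o1` gives 2000 nM. Compound 1 `Cc1cccc(Nc2nccc(-c3cc(C)oc3C)n2)c1` gives 28500 nM. Compound 2 `CN(C)c1ccc(Nc2nccc(-c3ccncc3)n2)cc1` gives 3700 nM; against compound 3 it sits within the scatter, while against compound 1 the gap lies beyond it. Compound 1 is made from compound 3 by methyl in place of hydrogen on an aromatic carbon and the step is a 14-fold higher number from compound 3 to compound 1 (1.15 log units; beyond the scatter), a large loss in this assay. Compound 2 and compound 3 share a related core, but the difference between the two cores is not broken down here.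

Compound 4 `Cc1cc(-c2ccncc2)nc(Nc2ccc(N(C)C)cc2)n1` has not yet been measured in this assay. It arises from compound 2 by methyl in place of hydrogen on an aromatic carbon. Among the compounds with values here, this is the same kind of change as the one from compound 3 to compound 1, but not the same: there the methyl enters on a six-membered aromatic ring of carbon only, meta to a large group, whereas here it enters on a six-membered aromatic ring with two nitrogen, next to the ring nitrogen, meta to a pyridin-4-yl group and opposite the ring nitrogen. Within the data shown here, the only guide to its effect is the one measured step, which rests on a different ring. A loss in this assay is therefore expected for compound 4, but with a wide range, and the step from compound 2 is estimated as a 3.0-fold higher number from compound 2 to compound 4 (0.47 log units; beyond the scatter). On that basis compound 4 is expected to give about 11000 nM, between 3000 nM and 45000 nM.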

Compound 4, half-maximal inhibitory concentration: > 24000 nM
Compound 4 gave a limit, no number; the forecaster's own chance of this, stated with the estimate: 15%; at least 2.1-fold (0.33 log units) between middle value and limit.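

In this assay compound 4 gives > 24000 nM, which is a limit of the assay and not a number. Methyl in place of hydrogen on an aromatic carbon costs activity on this second core as well, with the step read as an at least 6.4-fold higher number from compound 2 to compound 4 (0.81 log units; beyond the scatter), so in these two pairs the direction of the change carries from one core to the other. This does not show that the size carries, since the true value of compound 4 is unknown, and the two methyl groups enter on different rings, so two pairs give no general rule for the series: the same change on two cores in this assay, a 14-fold higher number (1.15 log units; beyond the scatter) from compound 3 to compound 1 and an at least 6.4-fold higher number (0.81 log units; beyond the scatter) from compound 2 to compound 4; the limit leaves it open whether they differ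

Still open, from the compounds shown here alone, is whether the loss is tied to methyl itself or would also appear with a longer chain such as ethyl, or with a primary amine or a carboxylic acid, in the same place on the aromatic ring. Also open, going by these compounds, is whether a methyl on the ring with two nitrogen would cost as much on the core of compound 3 as it does on the core of compound 2, which would separate the effect of the place from that of the core.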